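A few compounds are considered here, and "the series" means these few. Any claim that something is new, unique, unknown or untested is made for them only; others in the source may bear on it.

Measured compounds:
compound 1, `Cc1nc(N)sc1CCCN/C(N)=N/C(=O)CCCCCCCC(=O)/N=C(\N)NCCCc1sc(N)nc1C`, giving 0.9
compound 2, `Cc1nc(N)sc1CCCN/C(N)=N/C(=O)CCCCCCCCC(=O)/N=C(\N)NCCCc1sc(N)nc1C`, giving 0.79
compound 3, `N/C(=N\C(=O)CCCCCCCCCCCCCCCCCCCCC(=O)/N=C(\N)NCCCc1c[nH]cn1)NCCCc1c[nH]cn1`, giving 0.19

These three values come from an in vitro functional assay on Sf9 cells for agonist activity at histamine H2 receptor (Cavia porcellus); on this read-out lower numbers stand for smaller maximal responses and higher numbers for larger maximal responses. Compound 2 stands second highest of the three. Its nearest neighbour is compound 1, whose value lies above it by an amount beyond the usual scatter; its furthest is compound 3, whose value lies far below it, again beyond the scatter. Compounds 1 and 2 share the same end groups and differ in the chain between them, while compound 3 carries different end groups and a much longer chain, so no single-point comparison among the measured compounds is available.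

The unmeasured compound 4, `Cc1nc(N)sc1CCCN/C(N)=N/C(=O)CCCCCCCCC(=O)/N=C(\N)NCCCc1cnc(N)s1`, is reached from compound 2 by one change: hydrogen in place of methyl on an aromatic carbon. The change is a hydrogen in place of a methyl on one aromatic carbon, leaving the rest of compound 2 untouched. Going by the values given here, with no comparable step among the measured compounds, the size of the step in this assay is open; a modest change, most likely none beyond the scatter or a slight fall, is expected rather than a large shift. Compound 4 is therefore estimated at 0.72, within 0.5 to 0.92, which would be an expected step of a number 0.070 lower from compound 2 to compound 4 (within the scatter).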

Compound 4, intrinsic activity: the largest response reached, as a fraction of the reference agonist's: 0.89
Compound 4: middle estimate off by 0.17, on the low side, and the stated range covers the measured number.
By their numbers in this assay, from the lowest: compound 3; then compounds 2, 4 and 1 (each within the scatter of the next, the first and the last beyond it).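

In this assay, going by these compounds alone, the change from 2-amino-4-methyl-1,3-thiazol-5-yl to 2-amino-1,3-thiazol-5-yl at one end of the molecule gives a number 0.10 higher from compound 2 to compound 4 (within the scatter), and this is the first comparison that differs in only one place. It shows that, with the other end group and the chain held constant, hydrogen can stand in place of methyl at this position, on the aromatic carbon next to the ring nitrogen, without a shift beyond the usual scatter in the maximal response. The methyl on this end of compound 2 is therefore not required for a large response on this read-out, although this single step cannot show whether the methyl has a small effect that lies within the scatter, and the data offer no explanation for the outcome.

The compounds shown leave open what a larger group, such as an ethyl or a chlorine, would give on this same aromatic carbon. They also leave open whether hydrogen in place of methyl on the second end group, or on both end groups of a shorter chain such as that of compound 1, would likewise stay within the scatter.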